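This account rests on a few compounds, and the source may have more. Where it says the series, first, only, none or still open, it means among the compounds named here.

Working notes on the amide series in a functional assay on C8166 cells (Homo sapiens) for cytotoxicity, read by MTT assay; a lower number here means that less compound is tolerated, a higher number that more compound is tolerated.

Compound 1 `Cc1cc(S(N)(=O)=O)ccc1NC(=O)COc1ccc(Cl)cc1NC(=O)c1ccccc1[N+](=O)[O-]` gives 54800 nM in this assay. Compound 2 `Cc1cc(S(N)(=O)=O)ccc1NC(=O)COc1ccc(Cl)cc1NC(=O)c1cccc([N+](=O)[O-])c1` gives 58800 nM in this assay; the step here is a 1.1-fold higher number from compound 1 to compound 2 (0.03 log units; within the scatter). Compound 3 `Cc1ccc(C(=O)Nc2cc(Cl)ccc2OCC(=O)Nc2ccc(S(N)(=O)=O)cc2C)c(C)c1` gives 47600 nM in this assay. Measured against compound 1 the step is a 1.2-fold lower number from compound 1 to compound 3 (0.06 log units; within the scatter), and against compound 2 it is a 1.2-fold lower number from compound 2 to compound 3 (0.09 log units; within the scatter). Compound 3 thus stands together with compound 1 and compound 2: none of the three numbers is separated from another beyond the scatter, and the exchange of the aryl group on the carbonyl carbon has so far produced no change that can be read.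

Compound 4 `Cc1cc(S(N)(=O)=O)ccc1NC(=O)COc1ccc(Cl)cc1NC(=O)c1cc(Cl)cc(C#N)c1` is not yet measured in this assay. Its difference from compound 3 is 3-chloro-5-cyanophenyl in place of 2,4-dimethylphenyl on a carbonyl carbon. Among the compounds with values here, the steps that bear on this are the three noted above, each an exchange of the aryl group on the same carbonyl carbon, and each within the scatter. A 3-chloro-5-cyanophenyl has not been seen in the series, so the data offer no ground for a shift beyond the scatter in either direction. The expected step from compound 3 is a 1.1-fold higher number from compound 3 to compound 4 (0.04 log units; within the scatter), that is, none beyond the scatter. Compound 4 is estimated at 52000 nM, with a range from 28000 nM to 100000 nM.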

Compound 4, half-maximal cytotoxic concentration: 131000 nM
The estimate for compound 4 lay 2.5-fold (0.40 log units) below the measured number; measured number above the stated range.
By their numbers in this assay, from the lowest: compounds 3, 1 and 2 (each within the scatter of the next); then compound 4.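

The aryl group on the carbonyl carbon is not indifferent in this assay after all: 3-chloro-5-cyanophenyl gives a 2.8-fold higher number from compound 3 to compound 4 (0.44 log units; beyond the scatter) and a 2.2-fold higher number from compound 2 to compound 4 (0.35 log units; beyond the scatter) and a 2.4-fold higher number from compound 1 to compound 4 (0.38 log units; beyond the scatter) while the exchanges among 2-nitrophenyl, 3-nitrophenyl and 2,4-dimethylphenyl had moved nothing beyond the scatter. Compound 4 therefore stands alone as the compound of which more is tolerated, and all three steps to it are modest, so the position has shown a real but small range within these four compounds. Nothing at hand gives a measured property that would account for this change, so the step stands as an observation without an explanation.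

The entering group carries a chlorine and a nitrile together, and the compounds shown do not tell which of the two goes with the higher number; a 3-chlorophenyl and a 3-cyanophenyl on the same carbonyl carbon would separate them. As far as these compounds go, it also stays open whether the number moves further with a group of another kind at this position, such as a cyclohexyl or a phenyl bearing a carboxylic acid.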